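From 2-chlorophenyl to 3-bromophenyl

The compounds below may be only part of what the source reports. "The series", "measured", "known", "first", "only" and "open" are said of these compounds alone.

Measured in a functional assay on SW-620 cells (Homo sapiens) for cytotoxicity, read by MTT assay, with a stated time of 72 h; a lower number here means a stronger inhibitor, a higher number a weaker inhibitor:
Compound 1 `COc1ccccc1/C=C1\CCC/C(=C\c2cccc(OC)c2OC)C1=O`: > 20000 nM, a limit of the assay
Compound 2 `COc1cccc(/C=C2\CCC/C(=C\c3cc(Cl)cc(Cl)c3)C2=O)c1OC`: 5500 nM
Compound 3 `COc1ccc(/C=C2\CCC/C(=C\c3ccccc3Cl)C2=O)cc1OC`: 7100 nM

For the measured compounds named here, compound 3 stands within the scatter of compound 2, and these are the only two exact numbers. The change to the unmeasured compound 4 `COc1ccc(/C=C2\CCC/C(=C\c3cccc(Br)c3)C2=O)cc1OC` is 3-bromophenyl in place of 2-chlorophenyl on a double-bonded chain carbon bound to a double-bonded ring carbon. Going by the values given here, one measured step bears on this place, an at least 3.6-fold lower number from compound 1 to compound 2 (0.56 log units; beyond the scatter), and it starts from a limit. That step removed 2-methoxyphenyl, a group not involved here, so it gives no reason to expect a shift in this assay. The expected step, none beyond the scatter, is a 1.1-fold lower number from compound 3 to compound 4 (0.04 log units; within the scatter). For compound 4 the estimated value is 6500 nM, with an expected range from 2800 nM to 15000 nM.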

Compound 4, half-maximal inhibitory concentration: 4200 nM
Compound 4: middle estimate off by 1.5-fold (0.19 log units), on the high side, within the range that was stated.
By their numbers in this assay, from the lowest: compounds 4, 2 and 3 (each within the scatter of the next). At a limit, above all of these: compound 1.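

Replacing 2-chlorophenyl with 3-bromophenyl on a double-bonded chain carbon bound to a double-bonded ring carbon gives a 1.7-fold lower number from compound 3 to compound 4 (0.23 log units; within the scatter), the first step read directly at this place in this assay. These two halogen-bearing phenyl groups therefore cannot be told apart in this assay. Compound 1 alone remains a limit and not a number: the limit of > 20000 nM in this assay, at which 1 of the 4 values shown sits.

The step alters both the halogen and the name's ring number, so the compounds shown cannot separate the two changes. As far as these compounds go, what an amine or a carboxylic acid on this phenyl ring would do remains open.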